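Fluoro to cyano on the shared core

A few compounds are considered here, and "the series" means these few. Any claim that something is new, unique, unknown or untested is made for them only; others in the source may bear on it.

Compound 1 `c1ccc(C2CCc3nc[nH]c3C2)cc1`: in a functional assay on CHO cells for agonist activity at Alpha-1D adrenergic receptor (Homo sapiens), read by FLIPR and calcium flux (a higher number here means that more compound is needed for the effect, a lower number that less compound is needed), compound 1 returns > 10000 nM; > 10000 nM; > 10000 nM (3 entries), a limit of the assay rather than a number.
Compound 2 `Fc1ccccc1C1Cc2nccn2C1`: in this assay compound 2 gives 301 nM.

Going by the values given here, compound 2 therefore holds the only number on record. Compound 1 contributes a limit alone. The move to compound 3 `N#Cc1ccccc1C1Cc2nccn2C1` puts (cyano in place of fluoro on an aromatic carbon). Among the compounds with values here, no step between two measured compounds exists to calibrate it, so the size of the change in this assay is open; a modest shift in either direction, or none beyond the scatter, seems plausible. Compound 3 is expected near 400 nM, within 100 nM to 2000 nM. The estimated step of a 1.3-fold higher number from compound 2 to compound 3 (0.12 log units; within the scatter) is accordingly small.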

Compound 3, half-maximal effective concentration: > 10000 nM
Compound 3: no number, only a limit (the forecaster's own chance of this, stated with the estimate: 15%); middle value at least 25-fold (1.39 log units) from the limit.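

In this assay, this aromatic carbon of the shared core proves sensitive to its substituent: cyano in place of fluoro gives an at least 33-fold higher number from compound 2 to compound 3 (1.52 log units; beyond the scatter). Going by these compounds alone, this is the first step read, and it shows that a measurable number at fluoro does not carry over to cyano. Compound 3 stands at a limit of the assay rather than a number, so the step gives only a minimum size: the limit of > 10000 nM in this assay, at which 1 of the 3 values shown sits.

Going by these compounds, how far compound 3 lies beyond that limit remains open. So does whether chlorine, methoxy or an amine on this aromatic carbon would give a measurable number.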